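This account rests on a few compounds, and the source may have more. Where it says the series, first, only, none or still open, it means among the compounds named here.

The set here rests on two measured compounds and one that remains to be tested. Compound 1 `Cc1cccc(Cn2c(CN3CCN(C(=O)C4CCCC4)CC3)nc3ccccc32)c1` was run in an assay on isolated protein for inhibition of aldehyde dehydrogenase 1A1 (Homo sapiens), read by spectrophotometry, tested at 10 uM (a lower number here means less inhibition, a higher number more inhibition at the concentration tested (going by the name of the read-out)), and gives 67.5%. Compound 2 `O=C(C1CC1)N1CCN(Cc2nc3ccccc3n2Cc2ccc(Cl)cc2)CC1` gives 56.6% in this assay, a number lower than that of compound 1 by a margin beyond the usual scatter, so compound 1 holds the higher of the two numbers recorded so far. Compound 3 `Cc1cccc(Cn2c(CN3CCN(C(=O)c4cccs4)CC3)nc3ccccc32)c1` has not yet been measured in this assay. It differs from compound 1 in a single place: thiophen-2-yl in place of cyclopentyl on a carbonyl carbon. Going by the values given here, no step between measured compounds isolates this particular change, so nothing measured speaks directly to its size or direction. With compound 1 at 67.5% as the only anchor, the expectation is a change from compound 1 to compound 3 of about a number 7.5 percentage points lower from compound 1 to compound 3 (within the scatter), a shift that would stay within the scatter of the method rather than beyond it. Compound 3 is therefore estimated at 60%, with a range from 35% to 85%.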

Compound 3, a percentage reported as inhibition, at one concentration (the size of the read-out at that concentration, not a potency): 60.8%
Compound 3: middle estimate off by 0.8 percentage points, on the low side; low and high end bracket the measured number.
By their numbers in this assay, from the lowest: compounds 2, 3 and 1 (each within the scatter of the next, the first and the last beyond it).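

In this assay, going by these compounds alone, the step at this position reads a number 6.7 percentage points lower from compound 1 to compound 3 (within the scatter), the first step in the set that isolates a single place, here the group on a carbonyl carbon whose other neighbour is an amide-type nitrogen in a ring. It shows that cyclopentyl and thiophen-2-yl, both of 5 heavy atoms, cannot be told apart in this read-out at the concentration tested, even though a non-aromatic ring of carbon only gives way to an aromatic ring with a sulfur atom and a hydrogen-bond acceptor count of 1 instead of 0. No measurement in hand bears on why these two groups read alike.

Compound 2 also carries a different group on that carbonyl carbon, but it differs from compound 1 in a second place as well, so it cannot be read as a step at this position. Going by these compounds, whether a carboxylic acid, an amine or a longer alkyl chain on the same carbonyl carbon would move the number beyond the scatter stays open.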